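A few compounds are considered here, and "the series" means these few. Any claim that something is new, unique, unknown or untested is made for them only; others in the source may bear on it.

The measured compounds in this study are:

Compound 1, `CC(C)Cc1ccc2c(NCCCNCc3ccco3)ccnc2c1`, with 23 10^-6 cm/s in an ADME assay for permeability, using PAMPA, with a stated time of 30 min, at pH 7.4; on this read-out lower numbers stand for lower permeability and higher numbers for higher permeability.
Compound 2, `c1ccc(Oc2ccc3c(NCCCNCc4ccco4)ccnc3c2)cc1`, with 317 10^-6 cm/s in this assay.
Compound 3, `Fc1ccc(-c2ccc3c(NCCCNCc4ccco4)ccnc3c2)cc1`, with 237 10^-6 cm/s in this assay.

Compound 3 sits alongside compound 2: the step of a 1.3-fold lower number from compound 2 to compound 3 (0.13 log units; within the scatter) is within the scatter, so the two cannot be told apart. Against compound 1, however, compound 3 stands far higher, the step of a 10-fold higher number from compound 1 to compound 3 (1.01 log units; beyond the scatter) being beyond the scatter, as is the parallel step a 14-fold higher number from compound 1 to compound 2 (1.14 log units; beyond the scatter).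

Compound 4, `CC(C)CCc1ccc2c(NCCCNCc3ccco3)ccnc2c1`, has not yet been measured. It differs from compound 3 in one place: isopentyl in place of 4-fluorophenyl on an aromatic carbon. The change largely undoes the move that separated compound 3 from compound 1, since compound 1 carries isobutyl and compound 4 carries isopentyl, which is one carbon longer. Within the data shown here, no measured step speaks to that extra carbon alone; the only bearing steps are those from compound 1 to compound 2 and to compound 3, both large and both upward when an aromatic group replaced isobutyl. Going the other way, a large downward step is therefore expected in this assay, landing near compound 1 because of 23 10^-6 cm/s. The expected step is a 7.9-fold lower number from compound 3 to compound 4 (0.90 log units; beyond the scatter). Compound 4 is estimated at 30 10^-6 cm/s, with a range from 12 10^-6 cm/s to 80 10^-6 cm/s.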

Compound 4, apparent permeability: 23 10^-6 cm/s
Beside the measured number, compound 4's estimate is 1.3-fold (0.12 log units) above it; the measured number falls inside the stated range.
By their numbers in this assay, from the lowest: compounds 1 and 4 (each within the scatter of the next); then compounds 3 and 2 (each within the scatter of the next).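

In this assay, among these compounds, lengthening the saturated chain from isobutyl to isopentyl gives no change at the digits printed from compound 1 to compound 4 (within the scatter) and so leaves the read-out unresolved from the earlier chain compound, which the earlier compounds could not show. The large gap seen from isobutyl also recurs with a second saturated chain, as isopentyl in place of the aromatic groups gives a 10-fold lower number from compound 3 to compound 4 (1.01 log units; beyond the scatter) and a 14-fold lower number from compound 2 to compound 4 (1.14 log units; beyond the scatter) in the same assay. At this position the four compounds thus fall into two groups, with isobutyl and isopentyl in one and phenoxy and 4-fluorophenyl in the other, and no measurement offered here explains that split.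

The compounds shown leave open whether the split follows the aromatic ring itself or something else that separates these groups, and a saturated ring such as cyclohexyl or a benzyl group at this position would test that. They also leave open how a much longer chain, or a chain ending in an amine or a carboxylic acid, would behave on this same aromatic carbon.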